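Hydroxy to iodo on an inactive acid

The compounds below may be only part of what the source reports. "The series", "measured", "known", "first", "only" and "open" are said of these compounds alone.

In a functional assay on WM 266-4 cells (Homo sapiens) for inhibition, with a stated time of 72 h (on this read-out higher numbers stand for weaker inhibition and lower numbers for stronger inhibition), compound 1 `CNC(=O)C1=C[C@@H]2[C@@H](C(C)C)CC[C@@](O)(CO)[C@H]2C(=O)OC1` gives > 32000 nM, which is a limit of the assay and not a number. Compound 2 `CC(C)[C@H]1CC[C@@]2(CO2)[C@H]2C(=O)OCC(C(=O)OCc3ccc(-c4ccccc4)o3)=C[C@H]12` gives a true number, 960 nM. Compound 3 `CC(C)[C@H]1CC[C@@](O)(CO)[C@H]2C(=O)OCC(C(=O)O)=C[C@H]12` gives > 32000 nM, again only a limit. Compound 4 `CC(C)[C@H]1CC[C@@](O)(CI)[C@H]2C(=O)OCC(C(=O)O)=C[C@H]12` changes compound 3 by iodo in place of hydroxy on a saturated chain carbon bound to a saturated ring carbon, turning hydroxymethyl into iodomethyl. Among the compounds with values here, the one measured step that bears on this, a step that the two limits leave unreadable from compound 1 to compound 3, has no size to carry over, and the data sit largely at the limit of > 32000 nM in this assay, at which 2 of the 3 values shown sit. At most a small move towards stronger inhibition is therefore expected, and compound 4 may well stay at the limit. The expected change is an at least 1.2-fold lower number from compound 3 to compound 4 (0.10 log units; that floor lies within the scatter). For compound 4 the estimate is 25000 nM, with an expected range of 5000 nM to 32000 nM.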

Compound 4, half-maximal inhibitory concentration: 10100 nM
Beside the measured number, compound 4's estimate is 2.5-fold (0.39 log units) above it, and the stated range covers the measured number.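

Iodo in place of hydroxy on a saturated chain carbon bound to a saturated ring carbon gives an at least 3.1-fold lower number from compound 3 to compound 4 (0.50 log units; beyond the scatter) in this assay. Within the data shown here, this shows that a change at this position can move a compound with the free acid off the limit, which the earlier compounds did not show. As far as these compounds go, compound 3 gives > 32000 nM, which is a limit of the assay and not a number, so the full size of the step stays unknown.

From the compounds shown here alone, whether chloro, bromo or an amine on this carbon would act like iodo remains open.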